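Removing the Nitro Group Across Three Matched Carbamate Analogues

A few compounds are considered here, and "the series" means these few. Any claim that something is new, unique, unknown or untested is made for them only; others in the source may bear on it.

Of the compounds shown here, three with a shared core have been tested in a functional assay on HT-29 cells (Homo sapiens) for cytotoxicity, read by MTT assay, with a stated time of 72 h; on this read-out higher numbers stand for lower toxicity in this test and lower numbers for higher toxicity in this test. Compound 1 `CCCCOC(=O)Nc1ccc([Se]C#N)cc1` gives 63700 nM, compound 2 `CCCCCCOC(=O)Nc1ccc([Se]C#N)cc1` gives 69900 nM, and compound 3 `N#C[Se]c1ccc(NC(=O)OCc2ccc([N+](=O)[O-])cc2)cc1` gives 71900 nM. For the measured compounds named here, the single measured step, a 1.1-fold higher number from compound 1 to compound 2 (0.04 log units; within the scatter), lies within the scatter, and compound 3 stands within the scatter of both others, so the three numbers show no separation. Compound 4 `N#C[Se]c1ccc(NC(=O)OCc2ccccc2)cc1` differs from compound 3 by hydrogen in place of nitro on an aromatic carbon. Going by the values given here, no measured step covers this change; the only step available, a 1.1-fold higher number from compound 1 to compound 2 (0.04 log units; within the scatter), and the closeness of all three values give no ground to expect movement. The step from compound 3 to compound 4 is therefore expected to stay within the scatter, a 1.0-fold lower number from compound 3 to compound 4 (0.01 log units; within the scatter). Compound 4 is estimated at 70000 nM in this assay, between 35000 nM and 140000 nM.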

Compound 4, concentration lethal to 50% of the cells: 69100 nM
The estimate for compound 4 lay 1.0-fold (0.01 log units) above the measured number; the measured number falls inside the stated range.
By their numbers in this assay, from the lowest: compounds 1, 4, 2 and 3 (each within the scatter of the next).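

In this assay, hydrogen in place of nitro on an aromatic carbon, para to a large group, gives a 1.0-fold lower number from compound 3 to compound 4 (0.02 log units; within the scatter), so this position tolerates the loss of nitro without leaving the scatter. Phenyl in place of the saturated chains gives a 1.0-fold lower number from compound 2 to compound 4 (0.00 log units; within the scatter) and a 1.1-fold higher number from compound 1 to compound 4 (0.04 log units; within the scatter), so the four compounds remain unseparated. No independent evidence bears on this result. Open, as far as these compounds go, is whether an amine or a carboxylic acid on that aromatic carbon would separate from these numbers. Also open, from the compounds shown here alone, is whether a change to the selenocyanate-bearing part of the shared core would do so.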